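Cytotoxicity in liver cells: a chloro for methyl swap

This account rests on a few compounds, and the source may have more. Where it says the series, first, only, none or still open, it means among the compounds named here.

Measured so far:
compound 1 `Cc1ccccc1-n1cc(-c2ccccc2NS(=O)(=O)c2c[nH]c(=O)[nH]c2=O)nn1` — 56600 nM
compound 2 `Cc1ccc(-n2cc(-c3ccccc3NS(=O)(=O)c3c[nH]c(=O)[nH]c3=O)nn2)cc1` — > 100000 nM

The two compounds share a core and differ only in the aryl group on the aromatic nitrogen. In an ADME assay on L02 cells (Homo sapiens) for cytotoxicity, read by MTT assay, with a stated time of 24 h (a higher number here means that more compound is tolerated, a lower number that less compound is tolerated), compound 1 gives 56600 nM. For compound 2 the value of > 100000 nM is a limit of the assay, not a number, and it is the limit described as the limit of > 100000 nM in this assay, at which 1 of the 2 values shown sits. The step of an at least 1.7-fold higher number from compound 1 to compound 2 (0.24 log units; that floor lies within the scatter) is all that the measured pairs provide.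

Compound 3 `O=c1[nH]cc(S(=O)(=O)Nc2ccccc2-c2cn(-c3ccc(Cl)cc3)nn2)c(=O)[nH]1` is not yet measured. It differs from compound 2 by chloro in place of methyl on an aromatic carbon. Within the data shown here, no measured step covers a chloro for methyl exchange, and the one step that does exist, from the shift of the methyl on the ring, has a floor inside the scatter, so no shift beyond the scatter is expected. For compound 3 an estimate of 100000 nM with a range of 40000 nM to 250000 nM is therefore expected. The expected step for compound 3 is a number no higher from compound 2 to compound 3 (the limit leaves the size open).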

Compound 3, half-maximal cytotoxic concentration: 16800 nM
Compound 3: middle estimate off by 6.0-fold (0.77 log units), on the high side; the whole stated range lies above it.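

In this assay, among these compounds, the group on this aromatic carbon matters: chloro in place of methyl gives an at least 5.9-fold lower number from compound 2 to compound 3 (0.77 log units; beyond the scatter), whereas the only earlier step read an at least 1.7-fold higher number from compound 1 to compound 2 (0.24 log units; that floor lies within the scatter). Compound 3 also falls short of the other methyl compound, with a 3.4-fold lower number from compound 1 to compound 3 (0.53 log units; beyond the scatter), so among these three compounds it is the one tolerated least, with both of its steps printed as beyond the scatter. The value of compound 2 is a limit of the assay and not a number, so the step from it gives only a floor: the limit of > 100000 nM in this assay, at which 1 of the 3 values shown sits.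

The compounds shown leave open how far that step truly reaches and whether the lower number belongs to chloro alone or would also come with fluoro, bromo or methoxy at this place. They also leave open whether chloro would act the same way in the place the methyl holds in compound 1.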